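Oxadiazole in Place of Benzyloxy: Cytotoxicity Outlook

The compounds below may be only part of what the source reports. "The series", "measured", "known", "first", "only" and "open" are said of these compounds alone.

In an ADME assay on BJ cells (Homo sapiens) for cytotoxicity, read by CellTiter-Glo and resazurin assay, with a stated time of 72 h (a higher number here means that more compound is needed for the effect, a lower number that less compound is needed), the three measured compounds stand as follows, each at a limit of the assay rather than at a number:
Compound 1, `CC(=O)c1cccc(-c2ccc(C(=O)N(Cc3cccc(OCCCCCC(=O)O)c3)C(C)C)cc2)c1`: > 26000 nM
Compound 2, `CC(C)N(Cc1cccc(OCCCCCC(=O)O)c1)C(=O)c1ccc(-c2cccc(Oc3ccccc3)c2)cc1`: > 18700 nM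
Compound 3, `CC(C)N(Cc1cccc(OCCCCCC(=O)O)c1)C(=O)c1ccc(-c2cccc(OCc3ccccc3)c2)cc1`: > 26000 nM

Compound 3 thus stands only at a limit, (the limit of > 26000 nM in this assay, at which 2 of the 3 values shown sit). Compound 1 shares that limit. Compound 2 stands at the limit of > 18700 nM in this assay, at which 1 of the 3 values shown sits. Compound 4, `Cc1nnc(-c2cccc(-c3ccc(C(=O)N(Cc4cccc(OCCCCCC(=O)O)c4)C(C)C)cc3)c2)o1`, differs from compound 3 by 5-methyl-1,3,4-oxadiazol-2-yl in place of benzyloxy on an aromatic carbon. The measured steps that bear on this change are a step that the two limits leave unreadable from compound 1 to compound 2, a step that the two limits leave unreadable from compound 1 to compound 3 and a step that the two limits leave unreadable from compound 2 to compound 3; all three remain unreadable, so no size can be taken from them. Compound 4 is therefore expected to show the step that the limit leaves unreadable from compound 3 to compound 4, nothing beyond the scatter, in this assay. The estimate for compound 4 is 30000 nM, between 10000 nM and 100000 nM, most probably again reported only as a limit.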

Compound 4, half-maximal effective concentration: > 26000 nM
Compound 4 gave a limit, no number; the forecaster's own chance of this, stated with the estimate: 85%; the middle value does not contradict the limit.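

Among the compounds shown here, compound 4, like compound 1, compound 2 and compound 3, stands only at a limit, and no step to compound 4 can be read in this assay. The compounds shown leave open at what concentration any of them reaches the half-maximal effect, and whether the exchanged groups differ at all.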